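The source may report more compounds than this note shows. Statements on the series, on what has been measured and on what is new or still open speak of the compounds shown alone.

Working notes on the hydrazide series built on the shared core of compound 1, `O=C(CCc1ccccc1)NNc1c(Cl)cncc1Cl`. Within the data shown here, in a functional assay on HEK293 cells for antagonist activity at P2X purinoceptor 7 (Homo sapiens), read by fluorescence, with a stated time of 2 h (a higher number here means a weaker inhibitor, a lower number a stronger inhibitor), compound 1 gives 650 nM, the lowest of the three numbers so far. Compound 3, `O=C(CC1CCCCC1)NNc1c(Cl)cncc1Cl`, carries a saturated ring in place of the aromatic one and gives 730 nM in this assay, a value that sits within the scatter of compound 1, so no order between the two can be claimed. Among the measured compounds shown here, compound 2, `O=C(CCCCCc1ccccc1)NNc1c(Cl)cncc1Cl`, extends the chain toward the phenyl group by several carbons and gives 1900 nM in this assay, the only number that lies beyond the scatter from compound 1; the longer chain goes with a weaker inhibitor here, though this rests on one pair alone.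

Compound 4, `O=C(CCCC1CCCCC1)NNc1c(Cl)cncc1Cl`, is not yet measured. Against compound 1 the difference is cyclohexylmethyl in place of phenyl on a saturated chain carbon, two bonds along the chain from a carbonyl carbon, so compound 4 combines a saturated ring, as in compound 3, with a chain one carbon longer than that of compound 1. Since compound 3 shows 730 nM and compound 2 shows 1900 nM, a small shift toward a weaker inhibitor is expected, probably within or just at the edge of the scatter, as a 1.5-fold higher number from compound 1 to compound 4 (0.19 log units; within the scatter). The estimate for compound 4 in this assay is 1000 nM, with a range from 450 nM to 2500 nM.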

Compound 4, half-maximal inhibitory concentration: 360 nM
Compound 4: the middle estimate sits 2.8-fold (0.44 log units) above what was measured; the measured number lies below the stated range.
By their numbers in this assay, from the lowest: compounds 4, 1 and 3 (each within the scatter of the next, the first and the last beyond it); then compound 2.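

Exchanging phenyl for cyclohexylmethyl on a saturated chain carbon, two bonds along the chain from a carbonyl carbon, gives a 1.8-fold lower number from compound 1 to compound 4 (0.26 log units; within the scatter), so in this assay this position accepts the cyclohexylmethyl group with no change that can be told from the scatter. The earlier link between a longer chain and a weaker inhibitor rested on compound 2 alone and does not hold for compound 4, which goes against it; among the saturated-ring compounds, compound 3 gives 730 nM and compound 4 gives 360 nM, two numbers that lie beyond the scatter of each other. No measurement offered here accounts for these numbers.

Open, on these data alone, is how far the chain can grow on the saturated side, since a longer chain ending in a cyclohexyl ring would show whether the numbers in this assay keep falling or turn back as they do with the phenyl-ended chain of compound 2. Also open, as far as these compounds go, is whether the ring itself can change, for instance to a cyclopentyl ring, a piperidine ring or a cyclohexyl ring bearing a carboxylic acid.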